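A few compounds are considered here, and "the series" means these few. Any claim that something is new, unique, unknown or untested is made for them only; others in the source may bear on it.

Of the compounds shown here, three have been measured so far in an assay on LX2 cells for inhibition of COL1A1 promoter (Homo sapiens), read by a luciferase reporter, with a stated time of 24 h, tested at 50 uM; on this read-out lower numbers stand for a weaker effect and higher numbers for a stronger effect at the one concentration tested. Compound 1 `CN(C)c1ccc2c(=O)c(C(=O)Nc3cc(F)cc(F)c3)cn(-c3ccc(OCCCCCCC[N+]45CCN(CC4)CC5)cc3Cl)c2n1` gives 80%, compound 2 `Cc1cc(OCCCCCCC[N+]2(C)CCCCC2)cc(-n2cc(C(=O)Nc3cc(F)cc(F)c3)c(=O)c3ccc(N(C)C)nc32)c1` gives 79.7%, and compound 3 `CC[N+]1(CCCCCCCOc2ccc(-n3cc(C(=O)Nc4cc(F)cc(F)c4)c(=O)c4ccc(N(C)C)nc43)cc2Cl)CCCCC1` gives 50.4%. Compound 2 stands second highest of the three numbers; its reading and that of compound 1 lie within the scatter of each other, so no order between them can be claimed, while compound 3 sits beyond the scatter below both.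

The next compound, compound 4 `CC[N+]1(CCCCCCCOc2cc(C)cc(-n3cc(C(=O)Nc4cc(F)cc(F)c4)c(=O)c4ccc(N(C)C)nc43)c2)CCCC1`, differs from compound 2 in one place: a group of 7 heavy atoms (6 carbon, 1 nitrogen; one five-membered non-aromatic ring with 1 hetero atom) in place of a group of 7 heavy atoms (6 carbon, 1 nitrogen; one six-membered non-aromatic ring with 1 hetero atom), on a saturated chain carbon, seven bonds along the chain from an oxygen on an aromatic ring. The two share every atom, joined differently only in the size of the charged ring at the far end of the chain.

For the measured compounds named here, no pair of measured compounds differs in just one place, so no measured step guides this change directly. Given that compound 3, which also carries a charged ring of a different shape, reads lower, a modest drop is expected, though one that may stay inside the scatter. For compound 4 in this assay the estimate is 65%, within 40% to 85%, meaning an expected step of a number 14.7 percentage points lower from compound 2 to compound 4 (beyond the scatter).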

Compound 4, a percentage reported as inhibition, at one concentration (the size of the read-out at that concentration, not a potency): 73.2%
Compound 4: the middle estimate sits 8.2 percentage points below what was measured, within the range that was stated.
By their numbers in this assay, from the lowest: compound 3; then compounds 4, 2 and 1 (each within the scatter of the next).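

In this assay, putting a five-membered non-aromatic ring in place of a six-membered one at the charged end of the chain gives a number 6.5 percentage points lower from compound 2 to compound 4 (within the scatter), so the two readings cannot be told apart. For the compounds shown here, this is the first comparison that differs in one place, and it shows that this end group can be reshaped, with its atoms kept, without a clear effect on the read-out. Nothing measured here accounts for this result.

The swap also moves a carbon from the ring to the small group on the charged nitrogen, a methyl in compound 2 and an ethyl in compound 4, so these two features cannot be separated. On these data alone, how a seven-membered ring, a morpholine ring or a shorter chain would read remains open.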